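This account rests on a few compounds, and the source may have more. Where it says the series, first, only, none or still open, it means among the compounds named here.

Of the compounds shown here, three built on a shared core have been measured in a functional assay on LNCaP cells (Homo sapiens) for antiproliferative activity, read by MTT assay, with a stated time of 3 days; on this read-out lower numbers stand for stronger inhibition and higher numbers for weaker inhibition. Compound 1 `CCCS(=O)(=O)Nc1ccc(-c2cc(=O)c3c(O)cc(OC)c(OC(C)C)c3o2)cc1` gives 30500 nM, compound 2 `COc1cc(O)c2c(=O)cc(-c3ccc(NS(=O)(=O)C4CC4)cc3)oc2c1OC(C)C` gives 8800 nM, and compound 3 `C=CC(=O)Nc1ccc(-c2cc(=O)c3c(O)cc(OC)c(OC(C)C)c3o2)cc1` gives 15100 nM. Compound 3 therefore stands second highest of the three numbers: a 1.7-fold higher number from compound 2 to compound 3 (0.23 log units; within the scatter), while a 2.0-fold lower number from compound 1 to compound 3 (0.31 log units; beyond the scatter). Compound 4 `COc1cc(O)c2c(=O)cc(-c3ccc(NC(=O)N4CCN(C)CC4)cc3)oc2c1OC(C)C` differs from compound 3 by 4-methylpiperazin-1-yl in place of vinyl on a carbonyl carbon. Within the data shown here, no measured step alters the group on the carbonyl carbon in this way. The measured steps, a 3.5-fold lower number from compound 1 to compound 2 (0.54 log units; beyond the scatter) and a 2.0-fold lower number from compound 1 to compound 3 (0.31 log units; beyond the scatter), change the group on the sulfonyl sulfur or on the nitrogen on the aromatic ring, and both were modest. On that basis no step beyond the scatter is expected in this assay, and compound 4 is estimated at 15000 nM, within a range from 5000 nM to 45000 nM, which means an expected step of a 1.0-fold lower number from compound 3 to compound 4 (0.00 log units; within the scatter).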

Compound 4, half-maximal inhibitory concentration: 4500 nM
Estimate against measurement, compound 4: 3.3-fold (0.52 log units) above; measured number below the stated range.
By their numbers in this assay, from the lowest: compounds 4, 2 and 3 (each within the scatter of the next, the first and the last beyond it); then compound 1.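

In this assay, 4-methylpiperazin-1-yl in place of vinyl on the carbonyl carbon gives a 3.4-fold lower number from compound 3 to compound 4 (0.53 log units; beyond the scatter), so this group responds to a change that brings in a six-membered ring. On the nitrogen on the aromatic ring, (4-methylpiperazin-1-yl)carbonyl gives a 2.0-fold lower number from compound 2 to compound 4 (0.29 log units; within the scatter) against cyclopropylsulfonyl, and a 6.8-fold lower number from compound 1 to compound 4 (0.83 log units; beyond the scatter) against propylsulfonyl. No evidence at hand accounts for these steps. Still open, on these data alone, is whether morpholine, dimethylamine or a piperazine without its methyl group on the carbonyl carbon would give a similar number.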